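Swapping the Phenol for a Chloronitrophenyl on the Hydrazone

The compounds below may be only part of what the source reports. "The series", "measured", "known", "first", "only" and "open" are said of these compounds alone.

Compound 1 `CSc1nn(-c2ccccc2)c2ncnc(N/N=C/c3ccccc3O)c12` stands level with compound 2 `CSc1nn(-c2ccccc2)c2ncnc(N/N=C/c3cccc(O)c3)c12`, the two together the highest of three close numbers: in a functional assay on MCF7 cells (Homo sapiens) for inhibition, read by sulforhodamine B assay, with a stated time of 48 h (a higher number here means a weaker inhibitor, a lower number a stronger inhibitor), compound 1 gives 10.7 nM, and compound 2 gives 10.7 nM. Compound 3 `CSc1nn(-c2ccccc2)c2ncnc(N/N=C/c3ccc(O)cc3)c12` gives 10.3 nM. The three steps among them read no change at the digits printed from compound 1 to compound 2 (within the scatter), a 1.0-fold lower number from compound 1 to compound 3 (0.02 log units; within the scatter) and a 1.0-fold lower number from compound 2 to compound 3 (0.02 log units; within the scatter); none goes beyond the scatter. Compound 4 `CSc1nn(-c2ccccc2)c2ncnc(N/N=C/c3ccc([N+](=O)[O-])cc3Cl)c12` differs from compound 1 by 2-chloro-4-nitrophenyl in place of 2-hydroxyphenyl on a carbon with a double bond to nitrogen. Within the data shown here, no measured step exchanges the hydroxyl for other groups, so the known steps bear only indirectly, showing that moving the hydroxyl around the ring leaves the number unchanged. A step of a 1.2-fold higher number from compound 1 to compound 4 (0.08 log units; within the scatter) is therefore expected, with wide uncertainty. Compound 4 is estimated at 13 nM, between 4 nM and 45 nM.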

Compound 4, half-maximal inhibitory concentration: 15.7 nM
For compound 4 the middle estimate is 1.2-fold (0.08 log units) below the measured one, within the range that was stated.
By their numbers in this assay, from the lowest: compounds 3, 1, 2 and 4 (each within the scatter of the next).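

The earlier compounds shown here showed only that moving the hydroxyl around the ring left the number in place, whereas compound 4 has no hydroxyl at all and 2-chloro-4-nitrophenyl in its stead. In this assay this exchange stays within the scatter against all three phenols (a 1.5-fold higher number from compound 1 to compound 4 (0.17 log units; within the scatter) and a 1.5-fold higher number from compound 2 to compound 4 (0.17 log units; within the scatter) and a 1.5-fold higher number from compound 3 to compound 4 (0.18 log units; within the scatter)). No measured evidence explains this result.

The compounds shown leave open whether 2-chlorophenyl or 4-nitrophenyl alone would give the same reading. They also leave open how an amine or a carboxylic acid on this phenyl ring would read.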